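Ring amide nitrogen: phenyl removed in the shared core

A few compounds are considered here, and "the series" means these few. Any claim that something is new, unique, unknown or untested is made for them only; others in the source may bear on it.

Compound 2 `COc1ccc(C2Nc3ccccc3C(=O)N2c2ccccc2)cc1COc1ccc(NC(C)=O)cc1` is the larger of the two responses measured in a functional assay on HEK-EM293 cells for agonist activity at Thyrotropin receptor (Homo sapiens), read by ELISA and cAMP accumulation, with a stated time of 1 h; a lower number here means a smaller maximal response, a higher number a larger maximal response: compound 2 gives 75.1%. Compound 1 `COc1ccc(C2Nc3cccc(OC)c3C(=O)N2Cc2ccccc2)cc1COc1ccc(NC(C)=O)cc1` carries a benzyl on the ring nitrogen and a methoxy on the fused aromatic ring, and in this assay compound 1 gives 49.1%, a number that sits well below compound 2, beyond the usual scatter. Within the data shown here, no single-point step connects the two measured compounds, so the effect of the ring nitrogen substituent on its own has not been isolated.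

Compound 3 `COc1ccc(C2NC(=O)c3ccccc3N2)cc1COc1ccc(NC(C)=O)cc1` removes the substituent from that nitrogen entirely: hydrogen in place of phenyl on an amide-type nitrogen in a ring. Among the measured compounds shown here, nothing measured here shows what an unsubstituted ring nitrogen does; the one comparison available shows only that the two substituted forms differ in maximal response. For the measured compounds named here, a loss of maximal response relative to compound 2 is expected, of a size beyond the scatter, since the single comparison available points toward the substituent mattering; the step of a number 25.1 percentage points lower from compound 2 to compound 3 (beyond the scatter) is the estimated change. Compound 3 is expected to give 50% in this assay, with a range from 25% to 78%.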

Compound 3, largest response reached (Emax), in percent of the reference or control that the assay uses: 39.5%
The estimate for compound 3 lay 10.5 percentage points above the measured number; low and high end bracket the measured number.
By their numbers in this assay, from the lowest: compounds 3 and 1 (each within the scatter of the next); then compound 2.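

Among these compounds, the a number 35.6 percentage points lower from compound 2 to compound 3 (beyond the scatter) is the first single-point reading at this amide-type nitrogen in a ring: with hydrogen in place of phenyl and the rest of the shared core unchanged, the response in this assay drops by a large margin, so the effect of the substituent on this nitrogen no longer rests on a comparison blurred by a second structural difference. The phenyl is nevertheless not required for a response, since compound 3 still gives 39.5% in this series. No measurement at hand bears on why the response changes at this position.

Between hydrogen and phenyl, the shared core offers no further reading at this nitrogen, so a methyl, a cyclohexyl or a pyridyl there could fall anywhere relative to compound 2 and compound 3. The benzyl of compound 1 comes together with an added methoxy, which leaves the contribution of each of the two groups unseparated.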